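Adding an ethyl branch to the hydroxyethyl amide

The compounds below may be only part of what the source reports. "The series", "measured", "known", "first", "only" and "open" are said of these compounds alone.

Measured so far:
- compound 1, `COc1cccc2cc(C(=O)NCCO)c(=N)oc12`, 23% in an assay on HeLa cells for displacement of a labelled ligand from adenosine receptor A3 (Homo sapiens), read by scintillation counting, with a stated time of 180 min, tested at 10 uM; a higher number here means more inhibition at the concentration tested (going by the name of the read-out), a lower number less inhibition
- compound 2, `COc1ccc(-n2cnc(C#N)c2NC(=O)c2cc3cccc(OC)c3oc2=N)cc1`, 42% in this assay

Of the compounds shown here, two sharing one core have been tested in this assay. Compound 1 gives 23%, and compound 2 gives 42%. For the measured compounds named here, of these two numbers, the one for compound 1 is the lower, and compound 2 sits above it by a margin that exceeds the usual scatter of such measurements. No single-point change connects these two, so nothing can be said about which part of the difference between them carries that gap.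

Compound 3, `CCC(CO)NC(=O)c1cc2cccc(OC)c2oc1=N`, has not yet been measured. It differs from compound 1 in one place:

ethyl in place of hydrogen on a saturated chain carbon bound to an amide-type nitrogen and a saturated chain carbon

Going by the values given here, the amide part of the molecule is the only place that changes. Among the compounds with values here, with no comparable step among the measured compounds, the expectation for this assay is a move from compound 1 to compound 3 of a number 4 percentage points higher from compound 1 to compound 3 (within the scatter), that is, no change beyond the scatter in either direction. Compound 3 is therefore estimated at 27%, with a range from 10% to 45%.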

Compound 3, a percentage reported as inhibition, at one concentration (the size of the read-out at that concentration, not a potency): 6%
Compound 3: middle estimate off by 21 percentage points, on the high side; the measured number lies below the stated range.
By their numbers in this assay, from the lowest: compound 3; then compound 1; then compound 2.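

For the compounds shown here, the change from 2-hydroxyethyl to 1-(hydroxymethyl)propyl gives the only one-place comparison so far, and in this assay it amounts to a number 17 percentage points lower from compound 1 to compound 3 (beyond the scatter). This shows that the saturated chain carbon bound to the amide-type nitrogen is not indifferent to substitution: placing an ethyl there, with its 2 heavy atoms and no ring, while the hydroxyl stays on the chain and the shared core stays unchanged, is enough to give less inhibition at the concentration tested. Nothing shown here offers a measured explanation for this drop.

The compounds shown leave open whether a methyl on the same carbon would also lower the number, and whether a longer chain in place of the ethyl would lower it further or make no difference. Going by these compounds alone, they also leave open what an amine in place of the hydroxyl would do on either side chain, and with only a single step available, no trend can yet be drawn for this part of the amide.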